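A few compounds are considered here, and "the series" means these few. Any claim that something is new, unique, unknown or untested is made for them only; others in the source may bear on it.

Compound 1 `Nc1nc(N)c2c(-c3ccsc3)cn([C@@H]3O[C@H](CO)[C@@H](O)[C@H]3O)c2n1` was tested in a functional assay on HCT-116 cells (Homo sapiens), read by MTT assay, with a stated time of 72 h (on this read-out lower numbers stand for stronger inhibition and higher numbers for weaker inhibition), and gives > 20000 nM, which is a limit of this assay rather than a number.
Compound 2 `COc1ncnc2c1c(I)cn2[C@@H]1O[C@H](CO)[C@@H](O)[C@H]1O` gives > 20000 nM in this assay, again a limit and not a number.
Compound 3 `Cc1nc(N)c2c(-c3ccsc3)cn([C@@H]3O[C@H](CO)[C@@H](O)[C@H]3O)c2n1` gives > 20000 nM in this assay, also a limit.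

Compound 1 therefore stands at the limit of this assay, and none of the three measured compounds reaches a numerical value; all three sit at the limit of > 20000 nM in this assay, at which 3 of the 3 values shown sit. Going by the values given here, the only measured step among them, methyl in place of amino on an aromatic carbon, is a step that the two limits leave unreadable from compound 1 to compound 3, so its size cannot be read.

Compound 4 `Nc1nc(N)c2c(-c3ccccc3)cn([C@@H]3O[C@H](CO)[C@@H](O)[C@H]3O)c2n1` differs from compound 1 by phenyl in place of thiophen-3-yl on an aromatic carbon. Among the compounds with values here, no measured step bears directly on this change: the pair of compound 1 and compound 3 tells only that both remain at the limit, and compound 2 offers no step to any other compound. Because compound 1 sits at the limit of > 20000 nM in this assay, at which 3 of the 3 values shown sit, and every measured compound shares that position, the most likely outcome is that compound 4 also stays at the limit of this assay. The change is expected to amount to a step that the limit leaves unreadable from compound 1 to compound 4, in no readable direction. Compound 4 is estimated to give 30000 nM in this assay, with a range from 8000 nM to 100000 nM, most probably reported only as a limit.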

Compound 4, half-maximal inhibitory concentration: > 20000 nM
Compound 4 gave a limit, no number; the forecaster's own chance of this, stated with the estimate: 80%; the middle value lies beyond the limit too.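

Compound 4 gives > 20000 nM in this assay, again a limit and not a number, so no step can be read from compound 1 to compound 4. All the compounds shown share one position: the limit of > 20000 nM in this assay, at which 4 of the 4 values shown sit. They leave open whether any change on the shared core would give a numerical value in this assay.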